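The compounds below may be only part of what the source reports. "The series", "measured", "known", "first", "only" and "open" are said of these compounds alone.

Measured in an ADME assay on GES1 cells (Homo sapiens) for inhibition, read by MTT assay, with a stated time of 72 h; a higher number here means a weaker inhibitor, a lower number a stronger inhibitor:
- Compound 1 `Cc1cc(Nc2cc(-c3ccccc3)[nH]n2)n2nc(SCc3ccc(F)cc3)nc2n1`: 35500 nM
- Compound 2 `Cc1cc(Nc2cc(-c3ccccc3)[nH]n2)n2nc(SCC3CCCCC3)nc2n1`: > 50000 nM, which is a limit of the assay
- Compound 3 `Cc1cc(Nc2cc(-c3ccccc3)[nH]n2)n2nc(SCC(=O)c3ccccc3)nc2n1`: 33300 nM

Among the measured compounds shown here, compound 3 cannot be separated from the only other exact number, as the gap is a 1.1-fold lower number from compound 1 to compound 3 (0.03 log units; within the scatter). Compound 4 `Cc1cc(Nc2cc(-c3ccccc3)[nH]n2)n2nc(SCc3ccc(Cl)cc3)nc2n1` carries 4-chlorophenyl in place of benzoyl on a saturated chain carbon bound to a sulfur.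

Two further steps at this place run against the limit: an at least 1.4-fold higher number from compound 1 to compound 2 (0.14 log units; that floor lies within the scatter) and an at least 1.5-fold lower number from compound 2 to compound 3 (0.17 log units; that floor lies within the scatter). As far as these compounds go, their true size stays unknown. Compound 1, with its 4-fluorophenyl, is the closest match at 35500 nM, so no step beyond the scatter is expected. The expected change is a 1.0-fold lower number from compound 3 to compound 4 (0.00 log units; within the scatter). For compound 4 the estimated value is 33000 nM, with a range of 18000 nM to 50000 nM.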

Compound 4, half-maximal inhibitory concentration: 31800 nM
Compound 4: the middle estimate sits 1.0-fold (0.02 log units) above what was measured; measured number inside the range.
By their numbers in this assay, from the lowest: compounds 4, 3 and 1 (each within the scatter of the next). At a limit, above all of these: compound 2.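

In this assay, chloro in place of fluoro on an aromatic carbon gives a 1.1-fold lower number from compound 1 to compound 4 (0.05 log units; within the scatter), so this swap stays within the scatter here. 4-Chlorophenyl in place of benzoyl gives a 1.0-fold lower number from compound 3 to compound 4 (0.02 log units; within the scatter), so these two groups cannot be told apart at this position either. 4-Chlorophenyl in place of cyclohexyl gives an at least 1.5-fold lower number from compound 2 to compound 4 (0.19 log units; that floor lies within the scatter). Compound 2 stands at a limit, so the true size of this step stays unknown: the limit of > 50000 nM in this assay, at which 1 of the 4 values shown sits.

As far as these compounds go, whether an amine or a carboxylic acid on the saturated chain carbon bound to a sulfur would move the number beyond the scatter stays open. The same holds for a longer chain.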